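Two Measured Compounds and an Expected Third

This account rests on a few compounds, and the source may have more. Where it says the series, first, only, none or still open, it means among the compounds named here.

Measured so far:
compound 1, `CC1=C(C(=O)Nc2ccc([N+](=O)[O-])cc2)C(c2ccc(Br)cc2)N=C(SCc2ccccc2Cl)N1`, 6.7%
compound 2, `CC1=C(C(=O)Nc2ccc([N+](=O)[O-])cc2)C(c2cccc([N+](=O)[O-])c2)N=C(SCc2ccccc2)N1`, 7.7%

Both compounds were tested in a functional assay on the whole organism (artery, strain albino) with Rattus norvegicus as the target, with a stated time of 60 min, at a dose of 10 mg/kg by the oral route; on this read-out higher numbers stand for more inhibition at the one dose given (going by the name of the read-out) and lower numbers for less inhibition. Compound 1 gives 6.7% and compound 2 gives 7.7%. The two numbers lie within the usual scatter of each other, so neither can be said to show higher or lower inhibition in this assay than the other; compound 2 simply has the higher of the two figures, and both figures are low.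

Compound 3, `CC1=C(C(=O)Nc2ccc([N+](=O)[O-])cc2)C(c2cccc([N+](=O)[O-])c2)N=C(SCc2ccccc2Cl)N1`, has not yet been measured. It differs from compound 2 in one place: chloro in place of hydrogen on an aromatic carbon. The same kind of chloro group, on the same ring, is present in compound 1, which shows a low figure as well.

Nothing in the two measured values suggests that this change should move the read-out beyond the scatter. Compound 3 is therefore expected to give 7%, within a range of 0% to 18%. The expected step of a number 0.7 percentage points lower from compound 2 to compound 3 (within the scatter) is estimated to be no larger than the scatter.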

Compound 3, a percentage reported as inhibition, in the whole organism at one dose (the size of the read-out at that dose, not a potency): 6.7%
For compound 3 the middle estimate is 0.3 percentage points above the measured one; the measured number falls inside the stated range.
By their numbers in this assay, from the lowest: compounds 1, 3 and 2 (each within the scatter of the next).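

Among the compounds shown here, compound 3 gives the first clean reading of this change, since compound 1 and compound 2 differ in more than one place. In this assay, going from benzyl to 2-chlorobenzyl, with chloro in place of hydrogen ortho to a large group, gives a number 1 percentage points lower from compound 2 to compound 3 (within the scatter) and so does not separate the two compounds at this dose. The same compound also isolates the group on the saturated ring carbon, where 3-nitrophenyl in place of 4-bromophenyl gives no change at the digits printed from compound 1 to compound 3 (within the scatter) and likewise leaves no difference that can be read, while nothing shown gives a reason for either result.

With only these three compounds, each change has been read once, and neither can be said to matter in any other setting or at any other dose. Still open, from the compounds shown here alone, is whether a different kind of group on the benzylsulfanyl arm or on the saturated ring carbon, such as an amine, a carboxylic acid or a longer chain in place of benzyl, would move the figure in this assay beyond the usual scatter.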